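Hydroxymethylpiperidine Amide in Place of the Hydroxyethyl Chain

The source may hold more compounds than are shown below. What is called first, only, known or untested is meant among the compounds shown, and "the series" means these compounds.

Compound 1, `CC(C)(C)c1ccc(C(=O)N2CCC3(CC2)C(=O)N(CC(=O)NCCO)CN3c2ccccc2)cc1`, gives 1000 nM in an assay on HEK293 cells for displacement of a labelled ligand from NPC1-like intracellular cholesterol transporter 1 (Homo sapiens); on this read-out higher numbers stand for weaker inhibition and lower numbers for stronger inhibition.
Compound 2, `CC(C)(C)OC(=O)NCCNC(=O)CN1CN(c2ccccc2)C2(CCN(C(=O)c3ccc(C4CCCCC4)cc3)CC2)C1=O`, gives 5500 nM in this assay.
Compound 3, `CC(C)(C)OC(=O)NCCCCCNC(=O)CN1CN(c2ccccc2)C2(CCN(C(=O)c3ccc(C(C)(C)C)cc3)CC2)C1=O`, gives 13700 nM in this assay.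

Among these three, compound 1 carries the lowest number, and both other compounds lie beyond the scatter from it, compound 2 nearer and compound 3 furthest. All three share the same core and differ only in the amide tail and the aryl group.

Compound 4, `CC(C)(C)c1ccc(C(=O)N2CCC3(CC2)C(=O)N(CC(=O)N2CCCC(CO)C2)CN3c2ccccc2)cc1`, has not yet been measured. Compared with compound 1 the change is 3-(hydroxymethyl)piperidin-1-yl in place of (2-hydroxyethyl)amino on a carbonyl carbon. Among the measured compounds shown here, only one measured step touches the same tail: the step from compound 1 to compound 3 lengthens the chain and reads a 14-fold higher number from compound 1 to compound 3 (1.14 log units; beyond the scatter). Compound 2 differs from compound 1 in two places, so its value alone carries little. The tail in compound 4 is enlarged much less, keeps a hydroxyl and gains a ring, so a modest rise is expected, a 2.5-fold higher number from compound 1 to compound 4 (0.40 log units; beyond the scatter). For compound 4 the expected value in this assay is 2500 nM, within 800 nM to 8000 nM.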

Compound 4, half-maximal inhibitory concentration: 8200 nM
Estimate against measurement, compound 4: 3.3-fold (0.52 log units) below; the measured number lies above the stated range.
By their numbers in this assay, from the lowest: compound 1; then compounds 2, 4 and 3 (each within the scatter of the next, the first and the last beyond it).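

In this assay, putting 3-(hydroxymethyl)piperidin-1-yl in place of (2-hydroxyethyl)amino on a carbonyl carbon gives an 8.2-fold higher number from compound 1 to compound 4 (0.91 log units; beyond the scatter), so this position does not tolerate every tail that carries a hydroxyl. Before this result, the only single change measured here was one that replaced the hydroxyl, giving a 14-fold higher number from compound 1 to compound 3 (1.14 log units; beyond the scatter); the new step shows that keeping a hydroxyl is not enough to hold the value of compound 1. No measurement shown here accounts for the rise.

Still open, as far as these compounds go, is whether the ring or the loss of the amide hydrogen matters more, and a (2-hydroxyethyl)(methyl)amino group on the same carbonyl carbon would help separate the two. A plain piperidin-1-yl group would show what the hydroxymethyl adds to the ring.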